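A few compounds are considered here, and "the series" means these few. Any claim that something is new, unique, unknown or untested is made for them only; others in the source may bear on it.

Compound 1 `CCSc1nc2c(cc(-c3ccc(Cl)cc3)n2-c2ccccc2)c(=N)s1` and compound 2 `CCSc1nc2c(cc(-c3ccc(Br)cc3)n2-c2ccccc2)c(=N)s1` share one core and differ only by bromo in place of chloro on an aromatic carbon. In a functional assay on the whole organism for inhibition, with Rattus norvegicus as the target, read by ELISA, with stated times of 30 min and 6 h, at a dose of 30 mg/kg by the oral route (on this read-out lower numbers stand for less inhibition and higher numbers for more inhibition at the one dose given (going by the name of the read-out)), compound 1 gives 1%, and compound 2 gives 1%; the step of no change at the digits printed from compound 1 to compound 2 (within the scatter) lies within the scatter, so compound 2 stands level with compound 1, both giving almost no inhibition. Compound 3 `CCC(C)Sc1nc2c(cc(-c3ccc(Br)cc3)n2-c2ccccc2)c(=N)s1` differs from compound 2 by ethyl in place of hydrogen on a saturated chain carbon bound to a saturated chain carbon and a sulfur. Among the measured compounds shown here, no measured step alters this chain, so the numbers give no direction for the change. Compound 3 is therefore expected to move only by a number 4 percentage points higher from compound 2 to compound 3 (within the scatter). Compound 3 is estimated at 5%, in a range from 0% to 20%.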

Compound 3, a percentage reported as inhibition, in the whole organism at one dose (the size of the read-out at that dose, not a potency): 70%
Beside the measured number, compound 3's estimate is 65 percentage points below it; the measured number lies above the stated range.
By their numbers in this assay, from the lowest: compounds 1 and 2 (each within the scatter of the next); then compound 3.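

In this assay, extending the chain on the sulfur from ethyl to sec-butyl gives a number 69 percentage points higher from compound 2 to compound 3 (beyond the scatter). The earlier chloro-to-bromo exchange left the read-out unchanged, whereas this saturated chain carbon bound to a sulfur is a place where a small added group can change the result greatly. Nothing measured here explains the rise.

On these data alone, how a straight butyl chain, or a chain ending in an amine, would read at this place remains open. So does whether sec-butyl gives a similar rise with chloro in place of bromo.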